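Moving a Substituent Around the Phenyl Ring

The compounds below may be only part of what the source reports. "The series", "measured", "known", "first", "only" and "open" are said of these compounds alone.

Measured so far:
Compound 1 `COC(=O)C1=C(C)N=C(C)/C(=C(\O)OC)C1c1cccc(O)c1` — 1000 nM
Compound 2 `COC(=O)C1=C(C)N=C(C)/C(=C(\O)OC)C1c1ccc(F)cc1` — 129 nM
Compound 3 `COC(=O)C1=C(C)N=C(C)/C(=C(\O)OC)C1c1ccccc1Br` — 7.59 nM

These three compounds share a core and differ only in the aryl group on a saturated ring carbon. In a functional assay (muscle tissue) with Cavia porcellus as the target (a lower number here means that less compound is needed, a higher number that more compound is needed for the effect), compound 3 gives the lowest number of the three: a 17-fold lower number from compound 2 to compound 3 (1.23 log units; beyond the scatter) and a 130-fold lower number from compound 1 to compound 3 (2.12 log units; beyond the scatter). Compound 4 `COC(=O)C1=C(C)N=C(C)/C(=C(\O)OC)C1c1ccc(C#N)cc1` has not been measured; it differs from compound 3 by 4-cyanophenyl in place of 2-bromophenyl on a saturated ring carbon.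

The most relevant measured step runs the other way: a 17-fold lower number from compound 2 to compound 3 (1.23 log units; beyond the scatter). Compound 4, like compound 2, carries its substituent at the 4-position, so a large step back towards compound 2 is expected, with a higher number. The estimate for compound 4 is 200 nM, range 50 nM to 800 nM, meaning a step of a 26-fold higher number from compound 3 to compound 4 (1.42 log units; beyond the scatter).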

Compound 4, half-maximal effective concentration: 3470 nM
Beside the measured number, compound 4's estimate is 17-fold (1.24 log units) below it; measured number outside the range, above it.
By their numbers in this assay, from the lowest: compound 3; then compound 2; then compound 1; then compound 4.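

In this assay, the aryl group's substituent matters even when its site stays the same: cyano in place of fluoro on an aromatic carbon gives a 27-fold higher number from compound 2 to compound 4 (1.43 log units; beyond the scatter). 4-Cyanophenyl also ends above 3-hydroxyphenyl, with a 3.5-fold higher number from compound 1 to compound 4 (0.54 log units; beyond the scatter), and the gap to 2-bromophenyl reaches a 460-fold higher number from compound 3 to compound 4 (2.66 log units; beyond the scatter), the widest in this set. Nothing measured here accounts for these rises.

Still open, on these data alone, is whether the substituent or its site matters more. A 2-cyanophenyl or a 4-bromophenyl group would help to separate the two.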